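Imidazole for pyrrolidine on an alkyne-linked carbamate and urea series

The source may report more compounds than this note shows. Statements on the series, on what has been measured and on what is new or still open speak of the compounds shown alone.

Of the compounds shown here, three have been measured in a functional assay on the whole organism for agonist activity, with Mus musculus as the target; a lower number here means that less compound is needed, a higher number that more compound is needed for the effect. Compound 1 `COC(=O)N(C)C(C)C#CCN1CCCC1` gives 20.9 mg/kg. Compound 2 `COC(=O)N(C)C(C)C#CCn1ccnc1` gives 8 mg/kg. Compound 3 `CN(C)C(=O)N(C)CC#CCN1CCCC1` is known only as a limit of the assay, > 10 mg/kg, and not as a number. Compound 4 `CN(C)C(=O)N(C)CC#CCn1ccnc1` has not yet been measured in this assay.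

The change from compound 1 to compound 2 is 1H-imidazol-1-yl in place of pyrrolidin-1-yl on a saturated chain carbon bound to a triple-bonded carbon, and it gave a 2.6-fold lower number from compound 1 to compound 2 (0.42 log units; beyond the scatter). The change from compound 3 to compound 4 is 1H-imidazol-1-yl in place of pyrrolidin-1-yl on a saturated chain carbon bound to a triple-bonded carbon; it is the same change, at the same place, and it occurs twice among the compounds shown. The difference between the two cores, that of compound 1 and that of compound 3, is not broken down here.

Whether the step seen once on the core of compound 1 carries over to the core of compound 3 cannot be checked against a second measured pair. The starting point is weak as well, because the limit of > 10 mg/kg in this assay, at which 1 of the 3 values shown sits, leaves the true value of compound 3 open. The expected step is therefore set near the measured one but with wide bounds: the estimated step is a step that the limit leaves unreadable from compound 3 to compound 4. Compound 4 is expected to give about 12 mg/kg in this assay. The estimated range for compound 4 runs from 4 mg/kg to 40 mg/kg, and a further limit rather than a number is a real possibility.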

Compound 4, dose for half-maximal effect: > 100 mg/kg
Compound 4 was reported as a limit (the forecaster's own chance of this, stated with the estimate: 45%); at least 8.3-fold (0.92 log units) between middle value and limit.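

Compound 4, at > 100 mg/kg, is a limit of the assay and not a number. Compound 3, at > 10 mg/kg, is also a limit, so no step can be read between compound 3 and compound 4. The compounds shown leave open whether 1H-imidazol-1-yl in place of pyrrolidin-1-yl, which gave a 2.6-fold lower number from compound 1 to compound 2 (0.42 log units; beyond the scatter), carries over to the core of compound 3.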